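A few compounds are considered here, and "the series" means these few. Any claim that something is new, unique, unknown or untested is made for them only; others in the source may bear on it.

Working notes on the series. Among the measured compounds shown here, compound 1 `CC(C)(NC(=O)c1ccccc1-c1ccccc1)c1cc(C(F)(F)F)cc(C(F)(F)F)c1` is the first of the two measured compounds. In an assay on CHO cells for displacement of a labelled ligand from Substance-P receptor (Homo sapiens) (on this read-out higher numbers stand for weaker inhibition and lower numbers for stronger inhibition), compound 1 reaches only the limit > 10000 nM, which is a limit of the assay and not a number (the limit of > 10000 nM in this assay, at which 1 of the 2 values shown sits). For the measured compounds named here, compound 2 `Cc1ccccc1-c1cc(N2CCC(O)CC2)ncc1N(C)C(=O)C(C)(C)c1cc(C(F)(F)F)cc(C(F)(F)F)c1` is the second measured compound and the only one with an actual number: in this assay compound 2 gives 0.4 nM, so compound 2 stands as the sole numeric anchor of the series. Compound 3 `Cc1ccccc1-c1ccncc1N(C)C(=O)C(C)(C)c1cc(C(F)(F)F)cc(C(F)(F)F)c1` is the compound still to be measured. It differs from compound 2 in one place: hydrogen in place of 4-hydroxypiperidin-1-yl on an aromatic carbon. No step between measured compounds is available, so the size of this change cannot be read from the shown data. The change is expected to cost binding by a moderate step, beyond the usual scatter: a 7.5-fold higher number from compound 2 to compound 3 (0.88 log units; beyond the scatter). On that basis compound 3 is expected to give in this assay about 3 nM, with a likely range from 0.6 nM to 15 nM.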

Compound 3, inhibition constant: 3.4 nM
Compound 3: middle estimate off by 1.1-fold (0.05 log units), on the low side, within the range that was stated.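

In this assay, among the compounds shown here, replacing the 4-hydroxypiperidin-1-yl group on the aromatic carbon next to the ring nitrogen with hydrogen gives an 8.5-fold higher number from compound 2 to compound 3 (0.93 log units; beyond the scatter), the first single change whose size can be read. The position is therefore sensitive to this change, but the group is not essential for measurable binding: compound 3, with only hydrogen there, gives 3.4 nM in this assay, a real number and still a strong one on this read-out. Nothing shown gives a measured property of either group that could account for this step.

The compounds shown cannot separate a contribution of the piperidine ring from one of its hydroxyl, since only the whole 4-hydroxypiperidin-1-yl group and hydrogen appear at this position. A plain piperidin-1-yl group, a morpholin-4-yl group, a dimethylamino group or a carboxylic acid on the same carbon would be needed to tell which part of the substituent carries the step, and whether other groups there give a similar, smaller or larger change.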